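Cyclopropylmethyl on an aromatic nitrogen of compound 2

A few compounds are considered here, and "the series" means these few. Any claim that something is new, unique, unknown or untested is made for them only; others in the source may bear on it.

In a functional assay on K562 cells (Homo sapiens) for inhibition, read by trypan blue exclusion, with a stated time of 72 h (on this read-out lower numbers stand for stronger inhibition and higher numbers for weaker inhibition), compound 1 (`Cn1c(=O)c(S(=O)(=O)c2ccc(F)cc2F)cc2cnc(Nc3ccc4[nH]c(C(=O)O)cc4c3)nc21`) gives 10000 nM as its value. Compound 2 (`O=c1[nH]c2nc(Nc3ccc4[nH]ccc4c3)ncc2cc1S(=O)(=O)c1ccc(F)cc1F`) gives 15000 nM as its value, which lies within the scatter of compound 1, so the two cannot be told apart. Compound 3 (`O=c1c(S(=O)(=O)c2ccc(F)cc2F)cc2cnc(Nc3ccc4[nH]ccc4c3)nc2n1CC1CC1`) has cyclopropylmethyl in place of hydrogen on an aromatic nitrogen of compound 2 (cyclopropylmethyl in place of hydrogen on an aromatic nitrogen). Within the data shown here, no measured step isolates this change, so the expectation is tentative: in this assay a moderate move toward stronger inhibition is expected, with the estimated step (a 5.0-fold lower number from compound 2 to compound 3 (0.70 log units; beyond the scatter)) beyond the scatter. For compound 3 the estimated value is 3000 nM with an expected range from 500 nM to 15000 nM in this measurement.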

Compound 3, half-maximal inhibitory concentration: 1000 nM
Compound 3: middle estimate off by 3.0-fold (0.48 log units), on the high side; measured number inside the range.
By their numbers in this assay, from the lowest: compound 3; then compounds 1 and 2 (each within the scatter of the next).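

In this assay the exchange of hydrogen for cyclopropylmethyl on the aromatic nitrogen gives a 15-fold lower number from compound 2 to compound 3 (1.18 log units; beyond the scatter) and so shows that this position responds strongly to substitution. A carbon-only group with one three-membered ring is accepted there and goes with stronger inhibition. No available evidence bears on the reason for this gain. From the compounds shown here alone, whether a longer chain such as n-butyl, a larger ring such as cyclobutylmethyl or a chain ending in an amine would match cyclopropylmethyl remains open. The compounds shown also leave open how much of the gain depends on the ring itself.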